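From dimethoxyphenyl to dichlorophenyl: expecting little change

A few compounds are considered here, and "the series" means these few. Any claim that something is new, unique, unknown or untested is made for them only; others in the source may bear on it.

Of the compounds shown here, three that share one core have been measured in a functional assay on SF-539 cells (Homo sapiens) for inhibition, read by sulforhodamine B assay, with a stated time of 48 h; on this read-out lower numbers stand for stronger inhibition of growth and higher numbers for weaker inhibition of growth. Compound 1 `O=C(Cc1csc2nc(-c3ccc(Br)cc3)cn12)N/N=C/c1ccccc1` gives 16200 nM, compound 2 `O=C(Cc1csc2nc(-c3ccc(Br)cc3)cn12)N/N=C/c1ccc(O)cc1` gives 18200 nM, and compound 3 `COc1cccc(OC)c1/C=N/NC(=O)Cc1csc2nc(-c3ccc(Br)cc3)cn12` gives 11200 nM. Compound 3 thus stands within the usual scatter of both other compounds, so these three cannot be ranked against each other.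

The next compound, compound 4 `O=C(Cc1csc2nc(-c3ccc(Br)cc3)cn12)N/N=C/c1ccc(Cl)cc1Cl`, keeps the core and carries 2,4-dichlorophenyl in place of 2,6-dimethoxyphenyl on a carbon with a double bond to nitrogen.

For the measured compounds named here, three measured steps bear on this change. Putting 2,6-dimethoxyphenyl in place of phenyl gave a 1.4-fold lower number from compound 1 to compound 3 (0.16 log units; within the scatter). Putting it in place of 4-hydroxyphenyl gave a 1.6-fold lower number from compound 2 to compound 3 (0.21 log units; within the scatter). Hydroxy in place of hydrogen on the aromatic carbon gave a 1.1-fold higher number from compound 1 to compound 2 (0.05 log units; within the scatter). All three are small, so no step beyond the scatter is expected in this assay. Going by the values given here, the caution is that no measured compound yet carries chlorine on this group, so the range stays wide. The expected size of the change is a 1.2-fold higher number from compound 3 to compound 4 (0.06 log units; within the scatter).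

For compound 4 the estimated value is 13000 nM, with an expected range from 6500 nM to 26000 nM.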

Compound 4, concentration for 50% growth inhibition: 26900 nM
Compound 4: middle estimate off by 2.1-fold (0.32 log units), on the low side; the measured number lies above the stated range.
By their numbers in this assay, from the lowest: compounds 3, 1, 2 and 4 (each within the scatter of the next, the first and the last beyond it).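

For the compounds shown here, the swap at this carbon now gives the first step beyond the usual scatter in this assay: 2,4-dichlorophenyl in place of 2,6-dimethoxyphenyl is a modest change (a 2.4-fold higher number from compound 3 to compound 4 (0.38 log units; beyond the scatter)). Going by these compounds alone, the same group stays within the scatter when it replaces 4-hydroxyphenyl (a 1.5-fold higher number from compound 2 to compound 4 (0.17 log units; within the scatter)) or plain phenyl (a 1.7-fold higher number from compound 1 to compound 4 (0.22 log units; within the scatter)), so compound 4 cannot be separated from compound 2 or compound 1, and the only separated pair among the four compounds is compound 3 and compound 4. No measurement at hand accounts for this separation.

Chlorine appears here only as the pair in 2,4-dichlorophenyl, and the dimethoxy pattern only as 2,6-dimethoxyphenyl, so it remains open whether a single chlorine or a single methoxy on the ring would fall with compound 4, with compound 3 or somewhere else. Also open, going by these compounds, is whether a phenyl ring carrying an amine or a carboxylic acid, or a saturated ring in place of the phenyl, would move the number well outside the narrow band these four compounds occupy.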